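This account rests on a few compounds, and the source may have more. Where it says the series, first, only, none or still open, it means among the compounds named here.

Within the data shown here, in a physicochemical assay for lipophilicity (on this read-out higher numbers stand for higher lipophilicity and lower numbers for lower lipophilicity), compound 1 (`C=CC(C)(C)OC[n+]1ccn(C)c1/C=N/O`) gives -1.54 and compound 2 (`C=CCCOC[n+]1ccn(C)c1/C=N/O`) gives -1.84, so compound 2 stands within the scatter of compound 1, the only other measured compound. Compound 3 (`C#CC(C)OC[n+]1ccn(C)c1/C=N/O`) has not yet been measured. The change from compound 2 is 1-methylprop-2-yn-1-yl in place of but-3-en-1-yl on an oxygen on a saturated carbon. Among the measured compounds shown here, one measured step bears on it, at the same place but with a different group: a number 0.30 log units lower from compound 1 to compound 2 (within the scatter). For the measured compounds named here, that step stays within the scatter, and no measured step involves 1-methylprop-2-yn-1-yl, so the guidance is thin. No shift beyond the scatter is therefore expected in this assay. The expected step is a number 0.06 log units lower from compound 2 to compound 3 (within the scatter). For compound 3 the estimated value is -1.9, with an expected range from -2.25 to -1.55.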

Compound 3, distribution coefficient: -2.14
Compound 3: middle estimate off by 0.24 log units, on the high side, and the stated range covers the measured number.
By their numbers in this assay, from the lowest: compounds 3, 2 and 1 (each within the scatter of the next, the first and the last beyond it).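

Notes on the group on the oxygen: in this assay, 1-methylprop-2-yn-1-yl in place of but-3-en-1-yl gives a number 0.30 log units lower from compound 2 to compound 3 (within the scatter) and so does not separate these two groups, although a triple bond replaces a double bond at the same count of heavy atoms. Among these compounds, the same group in place of 1,1-dimethylprop-2-en-1-yl gives a number 0.60 log units lower from compound 1 to compound 3 (beyond the scatter) as the first step at this position to pass the scatter, so changes here can separate compounds, if only modestly. No supporting data explain either step.

As far as these compounds go, all three groups are unsaturated hydrocarbon chains, so it remains open how a saturated butyl group, a longer chain or a group carrying an amine or a hydroxyl would read at this position. From the compounds shown here alone, whether any such group would extend the spread seen so far also remains open.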